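Para-Substituent Swap on the Dichlorobenzimidazole Series

The compounds below may be only part of what the source reports. "The series", "measured", "known", "first", "only" and "open" are said of these compounds alone.

Notes on a two-compound anchor and one open step. Compound 1 `Nc1ccc(-c2nc3cc(Cl)c(Cl)cc3[nH]2)cc1` and compound 2 `Oc1ccc(-c2nc3cc(Cl)c(Cl)cc3[nH]2)cc1` share the dichlorinated core and differ only in the group on the distal benzene ring. In an ADME assay on BHK cells (Mesocricetus auratus) for cytotoxicity, read by MTT assay, with a stated time of 96 h (on this read-out higher numbers stand for lower toxicity in this test and lower numbers for higher toxicity in this test), compound 1 gives 30000 nM, and compound 2 gives 29000 nM. For the measured compounds named here, the only step on record, a 1.0-fold lower number from compound 1 to compound 2 (0.01 log units; within the scatter), shows that exchanging amino for hydroxy left the read-out unmoved. On the numbers shown compound 2 stands as the lowest of two, with compound 1 next to it, inside the scatter.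

Compound 3 `O=[N+]([O-])c1ccc(-c2nc3cc(Cl)c(Cl)cc3[nH]2)cc1` is the next member: nitro in place of hydroxy on an aromatic carbon. Going by the values given here, no step between a nitro and a hydroxy group has yet been measured, so the single recorded step is the only guide. Because a 1.0-fold lower number from compound 1 to compound 2 (0.01 log units; within the scatter) was flat, the step from compound 2 to compound 3 is expected to be small as well, a 1.2-fold lower number from compound 2 to compound 3 (0.06 log units; within the scatter), with no confident direction. Compound 3 is therefore estimated at 25000 nM, within 10000 nM to 60000 nM.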

Compound 3, half-maximal cytotoxic concentration: > 100000 nM
Compound 3: a limit, no number; the forecaster's own chance of this, stated with the estimate: 15%; at least 4.0-fold (0.60 log units) between middle value and limit.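

The aromatic carbon para to a large group is not indifferent to its substituent, something the flat amino-to-hydroxy pair could not show. Nitro brings an at least 3.4-fold higher number from compound 2 to compound 3 (0.53 log units; beyond the scatter) and an at least 3.3-fold higher number from compound 1 to compound 3 (0.52 log units; beyond the scatter) in the direction of lower toxicity in this test, so the two earlier groups read alike while the third stands apart from both. For compound 3 the read-out is a limit and not a number: the limit of > 100000 nM in this assay, at which 1 of the 3 values shown sits.

The compounds shown leave open which difference in nitro goes with this step, since its 3 heavy atoms, its 0 hydrogen-bond donors and its 2 hydrogen-bond acceptors all enter together. A nitrile or a carboxylic acid on the same aromatic carbon would test whether the higher number belongs to nitro alone.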